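The compounds below may be only part of what the source reports. "The series", "measured", "known", "first", "only" and "open" are said of these compounds alone.

Working notes on the series.

Three compounds of the shared core have numbers in a functional assay on Mahlavu cells (Homo sapiens) for antiproliferative activity, read by sulforhodamine B assay, with a stated time of 72 h; on this read-out lower numbers stand for stronger inhibition and higher numbers for weaker inhibition. Compound 1 `N#Cc1cccc(COc2ccc(-c3cc(CN4CCN(Cc5ccc(C(F)(F)F)cc5)CC4)no3)cc2)c1` gives 10600 nM and stands highest of the three. Compound 2 `Fc1ccccc1COc1ccc(-c2cc(CN3CCN(Cc4ccc(C(F)(F)F)cc4)CC3)no2)cc1` gives 3100 nM and compound 3 `Fc1ccc(COc2ccc(-c3cc(CN4CCN(Cc5ccc(C(F)(F)F)cc5)CC4)no3)cc2)cc1` gives 3100 nM. The step of a 3.4-fold lower number from compound 1 to compound 2 (0.53 log units; beyond the scatter) and the step of a 3.4-fold lower number from compound 1 to compound 3 (0.53 log units; beyond the scatter) both move the group on the saturated chain carbon bound to the oxygen; between them, no change at the digits printed from compound 2 to compound 3 (within the scatter).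

Compound 4 `N#Cc1cccc(COc2ccc(-c3cc(CN4CCN(c5ccc(F)cc5)CC4)no3)cc2)c1` is not yet measured. It differs from compound 1 at another place: 4-fluorophenyl in place of 4-(trifluoromethyl)benzyl on an amine nitrogen in a ring. Going by the values given here, none of the three measured steps touches the amine nitrogen in the ring, so no measured step bears directly on this change. Among the compounds with values here, the only information is that the group on the saturated chain carbon, kept as 3-cyanophenyl in compound 4, went with the highest number in compound 1.

Within the data shown here, with no step at the amine nitrogen to lean on, no change beyond the scatter is expected, and the estimated step is a 1.1-fold lower number from compound 1 to compound 4 (0.03 log units; within the scatter). Compound 4 is therefore expected near 10000 nM, with a wide range from 2500 nM to 40000 nM, and the measured number will say whether this position matters.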

Compound 4, half-maximal inhibitory concentration: 2200 nM
Estimate against measurement, compound 4: 4.5-fold (0.66 log units) above, outside the stated range (below it).
By their numbers in this assay, from the lowest: compounds 4, 2 and 3 (each within the scatter of the next); then compound 1.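

In this assay, the amine nitrogen in the ring proves to be a place that responds: with 3-cyanophenyl kept on the saturated chain carbon, 4-fluorophenyl in place of 4-(trifluoromethyl)benzyl gives a 4.8-fold lower number from compound 1 to compound 4 (0.68 log units; beyond the scatter) and so moves the number beyond the scatter. Going by these compounds alone, the earlier compounds varied only the group on the saturated chain carbon, so this is the first reading at the amine nitrogen, and the step is modest, as are the two steps away from 3-cyanophenyl at the other place. Nothing shown accounts for the lower number at compound 4, and the only record of the change is that a group of 11 heavy atoms leaves and one of 7 enters.

The change alters both the ring substituent and the attachment to the nitrogen, so the compounds shown cannot separate the two, and a 4-fluorobenzyl or a 4-(trifluoromethyl)phenyl group on the same nitrogen would be needed to do so. Also open, on these data alone, is whether the step carries over to the 2-fluorophenyl and 4-fluorophenyl compounds, or whether the amine nitrogen tolerates an acetyl group.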